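Series notes: methyl in place of chloro on compound 1

A few compounds are considered here, and "the series" means these few. Any claim that something is new, unique, unknown or untested is made for them only; others in the source may bear on it.

Three compounds have so far been run in a functional assay on SW480 cells (Homo sapiens) for cytotoxicity, read by MTT assay, with a stated time of 72 h; on this read-out lower numbers stand for stronger inhibition and higher numbers for weaker inhibition. Compound 1 `O=c1cc(CSc2nc3ccccc3s2)oc2ccc(Cl)cc12` returns in this assay only a limit, > 25000 nM, and no number. Compound 2 `Cc1cc(C)n2nc(SCc3nnc(SCc4cc(=O)c5ccccc5o4)n3-c3ccccc3)nc2n1` likewise returns only a limit in this assay, > 25000 nM. Among the compounds with values here, compound 3 `Cc1cc(C)n2nc(SCc3nnc(SCc4coc5ccccc5c4=O)s3)nc2n1` is the single compound with a measured number, giving 1500 nM in this assay. Within the data shown here, compound 1 therefore stands at the limit of > 25000 nM in this assay, at which 2 of the 3 values shown sit, without a number of its own to set against compound 3, and no measured compound differs from it in a single place, so no measured step starts from it.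

Compound 4 `Cc1ccc2oc(CSc3nc4ccccc4s3)cc(=O)c2c1` is not yet measured. It differs from compound 1 by methyl in place of chloro on an aromatic carbon. Among the measured compounds shown here, no measured pair reports the effect of such a change. Because compound 1 sits at the limit of > 25000 nM in this assay, at which 2 of the 3 values shown sit, the expectation for compound 4 is that the step that the limit leaves unreadable from compound 1 to compound 4 is none beyond the scatter, and that the read-out will most likely again be only a limit rather than a number. Compound 4 is expected to give about 40000 nM in this assay, within a range from 8000 nM to 200000 nM.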

Compound 4, half-maximal inhibitory concentration: > 25000 nM
Compound 4 gave a limit, no number; the forecaster's own chance of this, stated with the estimate: 75%; the middle value is on the limit's open side.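

Compound 1 and compound 4 both return only a limit in this assay, so no step can be read for methyl in place of chloro on an aromatic carbon: the limit of > 25000 nM in this assay, at which 3 of the 4 values shown sit.
The compounds shown leave open whether, in this assay, methyl and chloro on the shared core differ at all, as neither compound 1 nor compound 4 has a number of its own.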